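The source may hold more compounds than are shown below. What is called first, only, known or untested is meant among the compounds shown, and "the series" means these compounds.

Three related compounds already have numbers in an ADME assay on Caco-2 cells (Homo sapiens) for permeability, read by LC-MS, in the apical to basolateral direction, with a stated time of 60 min, at pH 6.5; a higher number here means that the compound crosses the layer faster, a lower number that the compound crosses the layer more slowly. Compound 1 (`CC(C)(C)[C@@H](O)C(=O)N1CCS[C@H]1C(=O)NCc1cc(Cl)ccc1-n1cnnn1`) gives 5.2 10^-6 cm/s, compound 2 (`O=C(NCc1cc(Cl)ccc1-n1cnnn1)[C@@H]1CC=NN1C(=O)[C@H](O)c1ccccc1F`) gives 8.9 10^-6 cm/s, and compound 3 (`CCCC(=O)O[C@@H](C(=O)N1N=CC[C@H]1C(=O)NCc1cc(Cl)ccc1-n1cnnn1)c1ccc(F)cc1`) gives 25 10^-6 cm/s. Compound 2 thus lies within the scatter of compound 1, while compound 3 stands beyond the scatter above compound 2.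

Compound 4 (`O=C(NCc1cc(Cl)ccc1-n1cnnn1)[C@@H]1CC=NN1C(=O)[C@H](O)Cc1ccccc1`) has not yet been measured. Its structure departs from that of compound 2 in one place: benzyl in place of 2-fluorophenyl on a saturated chain carbon bound to a carbonyl carbon and an oxygen on a saturated carbon. This puts benzyl in place of 2-fluorophenyl on a saturated chain carbon bound to a carbonyl carbon and an oxygen on a saturated carbon.

Among the measured compounds shown here, no measured pair differs in this place alone, so the data offer no direct guide to the change. No step beyond the scatter is expected in this assay, and the expectation stays anchored on compound 2 at 8.9 10^-6 cm/s. The estimated step, a 1.0-fold higher number from compound 2 to compound 4 (0.00 log units; within the scatter), is expected to remain within the scatter. For compound 4 the expected value is 9 10^-6 cm/s, with an estimated range from 4 10^-6 cm/s to 20 10^-6 cm/s.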

Compound 4, apparent permeability: 11 10^-6 cm/s
Compound 4: the middle estimate sits 1.2-fold (0.09 log units) below what was measured; low and high end bracket the measured number.
By their numbers in this assay, from the lowest: compounds 1, 2 and 4 (each within the scatter of the next, the first and the last beyond it); then compound 3.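

In this assay, benzyl in place of 2-fluorophenyl on a saturated chain carbon bound to a carbonyl carbon and an oxygen on a saturated carbon gives a 1.2-fold higher number from compound 2 to compound 4 (0.09 log units; within the scatter). This is the first pair shown that differs in one place alone, and it shows that this position takes this exchange, one group with a six-membered aromatic ring of carbon only for another, without a step beyond the scatter. No measurement at hand bears on why the two groups read alike.

Going by these compounds, whether an amine, a carboxylic acid or a longer chain at this place would also stay within the scatter remains open. Also open, on these data alone, is what plain phenyl would give here, which would separate the fluorine from the extra carbon of benzyl.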